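The source may hold more compounds than are shown below. What is called first, only, known or untested is meant among the compounds shown, and "the series" means these compounds.

Compound 1 `COc1cc(Br)c(C2C(C#N)=C(N)OC(c3c[nH]c4ccccc34)=C2C#N)cc1OC`: 880 ug/mL
Compound 2 `COc1ccc(C2C(C#N)=C(N)OC(c3c[nH]c4ccccc34)=C2C#N)cc1OC`: 867 ug/mL

Both compounds were tested in a functional assay; on this read-out lower numbers stand for stronger inhibition and higher numbers for weaker inhibition. For the measured compounds named here, compound 2 sits level with compound 1, the only other measured compound, so it cannot be ranked. The step of a 1.0-fold lower number from compound 1 to compound 2 (0.01 log units; within the scatter) lies within the scatter.

The next structure is compound 3 `Cc1ccccc1C1C(C#N)=C(N)OC(c2c[nH]c3ccccc23)=C1C#N`. It keeps the shared core, and the change is 2-methylphenyl in place of 3,4-dimethoxyphenyl on a saturated ring carbon.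

Going by the values given here, only one measured step bears on this change. The step of a 1.0-fold lower number from compound 1 to compound 2 (0.01 log units; within the scatter) put hydrogen in place of bromo on the same aromatic group that now leaves, and it moved the number no further than the scatter. Among the compounds with values here, that is a thin guide, since no measured compound tests the loss of the methoxy groups or the arrival of a methyl group. On this evidence, no shift beyond the scatter is expected, in either direction, and the estimated step is a 1.1-fold lower number from compound 2 to compound 3 (0.03 log units; within the scatter). The range stays wide to reflect how little has been tested. For compound 3 the expected value is 800 ug/mL, with an estimated range from 350 ug/mL to 1600 ug/mL.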

Compound 3, half-maximal inhibitory concentration: > 1000 ug/mL
Compound 3: no number, only a limit; the forecaster's own chance of this, stated with the estimate: 10%; at least 1.2-fold (0.09 log units) between middle value and limit.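

In this assay compound 3 gives > 1000 ug/mL as a limit of the assay, not as a number. This is the first change shown that replaces the whole aromatic group on the saturated ring carbon, rather than a single substituent on it, and the only reading available is an at least 1.1-fold higher number from compound 2 to compound 3 (0.06 log units; that floor lies within the scatter) as a floor on the true step. Swapping 3,4-dimethoxyphenyl for 2-methylphenyl is therefore not shown to shift the result beyond the scatter, yet a larger shift is not ruled out, and this is the one compound of the three without an exact number: the limit of > 1000 ug/mL in this assay, at which 1 of the 3 values shown sits.

From the compounds shown here alone, the loss of the two methoxy groups and the arrival of the methyl group come together in compound 3, so their separate contributions remain unknown, and a plain phenyl group on this carbon would help to pull them apart. Also open, going by these compounds, is how this assay would respond to a different kind of group at this place, such as a phenyl ring carrying a carboxylic acid or an amine.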